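The source may hold more compounds than are shown below. What is called first, only, known or untested is meant among the compounds shown, and "the series" means these compounds.

Measured so far in a functional assay on HT-29 cells (Homo sapiens) for inhibition, read by luminescence and CellTiter-Glo, with a stated time of 24 h; a lower number here means that less compound is needed, a higher number that more compound is needed for the effect:
compound 1, `CC(C)CCn1nc(C(=O)N[C@H]2COc3ccccc3N(C)C2=S)nc1Cc1ccccc1`, 3640 nM;
compound 2, `CN1C(=S)[C@@H](NC(=O)c2nc(Cc3ccccc3)n(CCCCCC#N)n2)COc2ccccc21`, 3830 nM;
compound 3, `CN1C(=S)[C@@H](NC(=O)c2nc(Cc3ccccc3)n(C3COC3)n2)COc2ccccc21`, 916 nM.

Compound 3 holds the lowest number of the three, with a 4.0-fold lower number from compound 1 to compound 3 (0.60 log units; beyond the scatter) and a 4.2-fold lower number from compound 2 to compound 3 (0.62 log units; beyond the scatter) both beyond the scatter, while a 1.1-fold higher number from compound 1 to compound 2 (0.02 log units; within the scatter) lies within it. Compound 4, `CN1C(=S)[C@@H](NC(=O)c2nc(Cc3ccccc3)n(Cc3ccccc3)n2)COc2ccccc21`, differs from compound 3 as follows: benzyl in place of oxetan-3-yl on an aromatic nitrogen. The two steps that reach compound 3 both replace a group on that same aromatic nitrogen with oxetan-3-yl and both lower the number; compound 4 runs that exchange the other way, so a modest rise is expected, of about a 2.7-fold higher number from compound 3 to compound 4 (0.44 log units; beyond the scatter). For compound 4 the expected value is 2500 nM, with a range of 900 nM to 7000 nM.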

Compound 4, half-maximal effective concentration: 414 nM
Beside the measured number, compound 4's estimate is 6.0-fold (0.78 log units) above it, and the stated range ends above it.
By their numbers in this assay, from the lowest: compound 4; then compound 3; then compounds 1 and 2 (each within the scatter of the next).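

On the aromatic nitrogen, benzyl gives a lower number than oxetan-3-yl (a change of a 2.2-fold lower number from compound 3 to compound 4 (0.34 log units; beyond the scatter)), so compound 3 no longer marks the low end at this position. Compound 4 also sits well below both open-chain compounds (a 9.3-fold lower number from compound 2 to compound 4 (0.97 log units; beyond the scatter); an 8.8-fold lower number from compound 1 to compound 4 (0.94 log units; beyond the scatter)). Among these four compounds, the two ring-bearing groups therefore rank below the isopentyl and 5-cyanopentyl chains, and the six-membered aromatic ring of benzyl ranks lowest.

Whether a fluorobenzyl, a phenethyl or a chain ending in an amine on this nitrogen would go lower remains open, and no measurement given here accounts for this order.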